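Bromo to Chloro Exchange: Notes Toward Compound 3

The source may hold more compounds than are shown below. What is called first, only, known or untested is meant among the compounds shown, and "the series" means these compounds.

Measured so far:
compound 1 `O=C1COc2ccc(-c3[nH]c(-c4ccc(F)cc4)nc3-c3ccccc3)cc2N1` — 37.5%
compound 2 `O=C1COc2ccc(-c3nn(-c4ccc(Br)cc4)cc3-c3ccccc3)cc2N1` — 58.8%

In a functional assay on A549 cells (Homo sapiens) for cytotoxicity, read by colorimetric assay and MTT assay, with a stated time of 3 days, tested at 20 uM (on this read-out higher numbers stand for a weaker effect at the one concentration tested and lower numbers for a stronger effect), compound 1 gives 37.5%. In the same this assay compound 2 gives 58.8%. Of the two numbers, compound 2 stands highest; its nearest neighbour is compound 1, which lies lower by a gap beyond the usual scatter. Going by the values given here, the two compounds differ in more than one place, so no single step between measured compounds is available.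

Compound 3 `O=C1COc2ccc(-c3nn(-c4ccc(Cl)cc4)cc3-c3ccccc3)cc2N1` has not yet been measured. It differs from compound 2 in one place: chloro in place of bromo on an aromatic carbon. The change keeps the heavy-atom count and the donor and acceptor counts unchanged. With no measured step of this kind in the series, the expectation is a step in this assay of no more than the scatter, in either direction, as a number 0.8 percentage points lower from compound 2 to compound 3 (within the scatter) is expected to show. The estimate for compound 3 is therefore 58%, with a range from 42% to 74%.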

Compound 3, a percentage reported as activity, at one concentration (the size of the read-out at that concentration, not a potency): 52.4%
For compound 3 the middle estimate is 5.6 percentage points above the measured one; measured number inside the range.
By their numbers in this assay, from the lowest: compound 1; then compounds 3 and 2 (each within the scatter of the next).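

Going by these compounds alone, the series now has its first single-place step: in this assay, the change from 4-bromophenyl to 4-chlorophenyl reads as a number 6.4 percentage points lower from compound 2 to compound 3 (within the scatter) and is the only direct reading of this position so far. On this aromatic carbon, para to a large group, the exchange of these two halogens therefore leaves compound 2 and compound 3 indistinguishable on this read-out, which the earlier comparison across several differences could not show. Nothing on hand gives a reason for this result.

Open, going by these compounds, is whether an amine or a carboxylic acid in place of the halogen on this aromatic carbon would move the number beyond the scatter. Also open, on these data alone, is whether the same chloro for bromo exchange would read alike on the core of compound 1, where the 4-fluorophenyl group stands.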